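Changing the chain end: from compound 3 to compound 4

This account rests on a few compounds, and the source may have more. Where it says the series, first, only, none or still open, it means among the compounds named here.

The series shares one core and varies the end of the chain. Compound 1 (`CC(C)(C)OC(=O)COCCCCCCn1nc(-c2ccccc2)c(-c2ccccc2)c1-c1ccccc1`) gives > 62000 nM in a functional assay for inhibition, with Homo sapiens as the target (on this read-out lower numbers stand for stronger inhibition and higher numbers for weaker inhibition), and this value is a limit of the assay. In this assay, compound 2 (`O=C(O)COCCCCCCn1nc(-c2ccccc2)c(-c2ccccc2)c1-c1ccccc1`) gives 440 nM. Compound 3 (`O=C(O)C[S+]([O-])CCCCCCn1nc(-c2ccccc2)c(-c2ccccc2)c1-c1ccccc1`) gives 6500 nM, the higher of the two true numbers, and the gap is a 15-fold higher number from compound 2 to compound 3 (1.17 log units; beyond the scatter).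

The next compound is compound 4 (`NC(=O)CCCCCCCCn1nc(-c2ccccc2)c(-c2ccccc2)c1-c1ccccc1`). The change is a group of 5 heavy atoms (3 carbon, 1 nitrogen, 1 oxygen; no ring) in place of a group of 6 heavy atoms (2 carbon, 3 oxygen, 1 sulfur; no ring), on a saturated chain carbon, six bonds along the chain from an aromatic nitrogen: 2-carbamoylethyl enters on a saturated chain carbon, six bonds along the chain from an aromatic nitrogen.

Compound 4 loses the carboxylic acid end shared by compound 2 and compound 3, which compound 1 also lacks. The most relevant measured steps are an at least 140-fold lower number from compound 1 to compound 2 (2.14 log units; beyond the scatter), which is large, and an at least 9.5-fold lower number from compound 1 to compound 3 (0.97 log units; beyond the scatter), which is at least modest. Among the measured compounds shown here, both favour the free acid end, and no measured compound goes against this, though compound 4 is a primary amide rather than an ester. A step towards weaker inhibition is therefore expected, estimated as a 3.1-fold higher number from compound 3 to compound 4 (0.49 log units; beyond the scatter) in this assay. For compound 4 the expected value is 20000 nM, with an estimated range of 4000 nM to 62000 nM.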

Compound 4, half-maximal inhibitory concentration: 33000 nM
The estimate for compound 4 lay 1.7-fold (0.22 log units) below the measured number; low and high end bracket the measured number.
By their numbers in this assay, from the lowest: compound 2; then compound 3; then compound 4. At a limit, above all of these: compound 1.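

In this assay, among the compounds shown here, compound 4 gives the first true number for a chain end without a carboxylic acid, and it sits on the weak side of both acids, with a 5.1-fold higher number from compound 3 to compound 4 (0.71 log units; beyond the scatter) and a 75-fold higher number from compound 2 to compound 4 (1.88 log units; beyond the scatter), while the comparison with compound 1 gives an at least 1.8-fold lower number from compound 1 to compound 4 (0.27 log units; that floor lies within the scatter). For the compounds shown here, all three true numbers thus keep the order of compound 2, then compound 3, then compound 4, and no compound with a true number goes against the acid ends giving the lower numbers, although the larger step swaps carboxymethoxy for 2-carbamoylethyl as a whole and does not separate the end group from the rest of the replaced chain. The step from compound 1 gives only a floor and no order of the two compounds, because the value of compound 1 is only a limit: the limit of > 62000 nM in this assay, at which 1 of the 4 values shown sits.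

The compounds shown leave open whether 2-carboxyethyl at this place, on a saturated chain carbon, six bonds along the chain from an aromatic nitrogen, would give a number close to that of compound 2 or of compound 3. They also leave open how an amine at the chain end, or a longer chain carrying the same carboxylic acid, would read in this assay.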